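Aryl exchange on the shared core: compound 2 to compound 3

The compounds below may be only part of what the source reports. "The series", "measured", "known", "first", "only" and "open" are said of these compounds alone.

Measured in an in vivo ADME assay on the whole organism (strain 129/SvEvBrd x C57BL/6) for pharmacokinetics, with Mus musculus as the target, at a dose of 1 mg/kg by the intravenous route; on this read-out higher numbers stand for fast clearance and lower numbers for slow clearance:
- compound 1 `OC[C@@H](O)[C@@H](O)[C@H](O)c1c[nH]c(-c2cocn2)n1`: 16.6 mL/min/kg
- compound 2 `OC[C@@H](O)[C@@H](O)[C@H](O)c1c[nH]c(-c2cnccn2)n1`: 13.4 mL/min/kg

Going by the values given here, compound 2 stands within the scatter of compound 1, the only other measured compound, so the two values give a single level for the series. Compound 3 `Cn1cnc(-c2nc([C@@H](O)[C@H](O)[C@H](O)CO)c[nH]2)c1` carries 1-methyl-1H-imidazol-4-yl in place of pyrazin-2-yl on an aromatic carbon. Among the compounds with values here, one measured step bears on this change, an exchange of group at the same carbon: a 1.2-fold lower number from compound 1 to compound 2 (0.09 log units; within the scatter). Within the data shown here, no measured compound carries the 1-methyl-1H-imidazol-4-yl group, so the new group remains untested and the range stays wide. The expected change is a 1.1-fold higher number from compound 2 to compound 3 (0.05 log units; within the scatter), with no shift expected beyond the scatter. For compound 3 the estimated clearance is 15 mL/min/kg, with an expected range of 8 mL/min/kg to 28 mL/min/kg.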

Compound 3, clearance: 9.1 mL/min/kg
For compound 3 the middle estimate is 1.6-fold (0.22 log units) above the measured one, within the range that was stated.
By their numbers in this assay, from the lowest: compounds 3, 2 and 1 (each within the scatter of the next).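

In this assay, a third group on the aromatic carbon between two ring nitrogen atoms, 1-methyl-1H-imidazol-4-yl, gives a 1.5-fold lower number from compound 2 to compound 3 (0.17 log units; within the scatter) when it replaces pyrazin-2-yl. Against 1,3-oxazol-4-yl it gives a 1.8-fold lower number from compound 1 to compound 3 (0.26 log units; within the scatter), so all three groups at this position, on one six-membered and two five-membered aromatic rings, stay within the scatter of one another. No independent measurement is available to account for this result.

As far as these compounds go, whether an amine or a carboxylic acid on this carbon would move clearance beyond the scatter remains open. Also open, from the compounds shown here alone, is what a change would do at the group of 8 heavy atoms on the shared core, which all three compounds carry unchanged.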